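The compounds below may be only part of what the source reports. "The series", "measured", "known", "first", "only" and "open" are said of these compounds alone.

Compound 1 `Cc1ccc(-c2noc(CCCCCCC(=O)NO)n2)cc1`: 1360 nM
Compound 2 `O=C(CCCCCCc1nc(-c2ccccc2Cl)no1)NO`: 750 nM
Compound 3 `O=C(CCCCCCc1nc(-c2cccc([N+](=O)[O-])c2)no1)NO`: 1160 nM

In a functional assay on U-937 cells (Homo sapiens) for antiproliferative activity, read by MTT assay, with a stated time of 72 h (on this read-out higher numbers stand for weaker inhibition and lower numbers for stronger inhibition), compound 1 stands within the scatter of the other two measured compounds, so the three values form one close group. Compound 4 `O=C(CCCCCCc1nc(-c2cccs2)no1)NO` has not been measured. It keeps the core of compound 1 and changes one group: thiophen-2-yl in place of 4-methylphenyl on an aromatic carbon. For the measured compounds named here, one measured step bears on this, because it swaps the group at the same place: a 1.8-fold lower number from compound 1 to compound 2 (0.26 log units; within the scatter). Compound 3, with a different ring group there, gives 1160 nM. Going by the values given here, no thiophen-2-yl compound has been measured yet, so no change beyond the scatter is expected in this assay. The expected step is a 1.4-fold lower number from compound 1 to compound 4 (0.13 log units; within the scatter). For compound 4 the estimated value is 1000 nM, with an expected range from 450 nM to 2200 nM.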

Compound 4, half-maximal inhibitory concentration: 320 nM
Compound 4: middle estimate off by 3.1-fold (0.49 log units), on the high side; the whole stated range lies above it.
By their numbers in this assay, from the lowest: compound 4; then compounds 2, 3 and 1 (each within the scatter of the next).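

In this assay, the earlier swaps at this aromatic carbon stayed within the scatter, but thiophen-2-yl goes beyond it, with a 4.3-fold lower number from compound 1 to compound 4 (0.63 log units; beyond the scatter) and a 2.3-fold lower number from compound 2 to compound 4 (0.37 log units; beyond the scatter). This shows that the group at this place can change the result, and that here a five-membered aromatic ring with one sulfur atom gives a lower number than either phenyl group it replaces. Nothing available explains this difference. The compounds shown leave open whether furan-2-yl, thiophen-3-yl or a pyridine ring would match thiophen-2-yl, and whether the sulfur atom or the smaller ring accounts for the step.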